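The compounds below may be only part of what the source reports. "The series", "measured", "known", "first", "only" and "open" are said of these compounds alone.

Compound 1 `O=C(Nc1cccc(-c2oc3cc(-c4ccc(F)cc4)ccc3c(=O)c2O)c1)c1ccc(Cl)cc1` gives 4730 nM in a functional assay on MCF7 cells (Homo sapiens) for antiproliferative activity, read by CCK-8 assay, with a stated time of 72 h; a lower number here means a stronger inhibitor, a higher number a weaker inhibitor.
Compound 2 `O=C(Nc1cccc(-c2oc3cc(-c4ccc(F)cc4)ccc3c(=O)c2O)c1)c1ccc(F)cc1F` gives 13500 nM in this assay.
Compound 3 `N#Cc1ccc(C(=O)Nc2cccc(-c3oc4cc(-c5ccc(F)cc5)ccc4c(=O)c3O)c2)cc1` gives 2660 nM in this assay.

Among these three, compound 2 stands highest, with steps to both others beyond the scatter: a 2.9-fold higher number from compound 1 to compound 2 (0.46 log units; beyond the scatter) and a 5.1-fold lower number from compound 2 to compound 3 (0.71 log units; beyond the scatter). Compound 4 `O=C(Nc1cccc(-c2oc3cc(-c4ccc(F)cc4)ccc3c(=O)c2O)c1)c1ccc([N+](=O)[O-])cc1` has not yet been measured in this assay. It differs from compound 2 in one place: 4-nitrophenyl in place of 2,4-difluorophenyl on a carbonyl carbon. The two steps that bear on this are those that exchange the 2,4-difluorophenyl for a 4-substituted phenyl, each of which moved the number down by a modest amount beyond the scatter, a 5.1-fold lower number from compound 2 to compound 3 (0.71 log units; beyond the scatter) and, read backwards, a 2.9-fold higher number from compound 1 to compound 2 (0.46 log units; beyond the scatter). A modest lower number is therefore expected for compound 4, a 3.9-fold lower number from compound 2 to compound 4 (0.59 log units; beyond the scatter), landing near the values of compound 1 and compound 3. The estimate for compound 4 is 3500 nM, with a range from 1200 nM to 10000 nM.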

Compound 4, half-maximal inhibitory concentration: 3970 nM
For compound 4 the middle estimate is 1.1-fold (0.05 log units) below the measured one; low and high end bracket the measured number.
By their numbers in this assay, from the lowest: compounds 3, 4 and 1 (each within the scatter of the next); then compound 2.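

Replacing 2,4-difluorophenyl with 4-nitrophenyl on the carbonyl carbon gives a 3.4-fold lower number from compound 2 to compound 4 (0.53 log units; beyond the scatter) in this assay and so a third group parts from compound 2. Nitro in place of cyano gives a 1.5-fold higher number from compound 3 to compound 4 (0.17 log units; within the scatter) and nitro in place of chloro gives a 1.2-fold lower number from compound 1 to compound 4 (0.08 log units; within the scatter) so these three phenyl groups sit together, with compound 2 alone apart. Nothing measured here says why these groups fall together.

Going by these compounds, whether an amine, a carboxylic acid or a methoxy group on that phenyl would stay with compound 1, compound 3 and compound 4 remains open. So does whether 4-fluorophenyl would part from them as the 2,4-difluorophenyl of compound 2 does.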